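Fluoro in place of benzyloxy on an indanone-type inhibitor

The source may report more compounds than this note shows. Statements on the series, on what has been measured and on what is new or still open speak of the compounds shown alone.

Measured compounds:
- compound 1 `O=C(c1ccc(OCCCN2CCCCC2)cc1)C1CC1`, an assay for inhibition of Amine oxidase [flavin-containing] B (Homo sapiens), read by fluorescence, with a stated time of 20 min; on this read-out higher numbers stand for weaker inhibition and lower numbers for stronger inhibition: 3880 nM
- compound 2 `O=C1/C(=C/c2ccc(OCCCN3CCCCC3)cc2)Cc2cc(OCc3ccc(Br)cc3)ccc21`, this assay: 276 nM

Of the two numbers, compound 2 gives the lower one, and its gap to compound 1 lies beyond the scatter of the method, so compound 2 stands as the stronger inhibitor of the pair. Compound 3 `O=C1/C(=C/c2ccc(OCCCN3CCCCC3)cc2)Cc2cc(F)ccc21` differs from compound 2 in one place: fluoro in place of (4-bromobenzyl)oxy on an aromatic carbon. Among the compounds with values here, no measured pair shows this change, so its effect has to be judged from the change itself. A large group leaves and a single atom enters, and the number is expected to rise, that is, inhibition is expected to weaken, by a step well beyond the scatter, a 5.4-fold higher number from compound 2 to compound 3 (0.74 log units; beyond the scatter). Compound 3 is therefore estimated at 1500 nM, with a plausible range from 300 nM to 8000 nM.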

Compound 3, half-maximal inhibitory concentration: 1930 nM
Estimate against measurement, compound 3: 1.3-fold (0.11 log units) below, within the range that was stated.
By their numbers in this assay, from the lowest: compound 2; then compounds 3 and 1 (each within the scatter of the next).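

In this assay, within the data shown here, the exchange of (4-bromobenzyl)oxy for fluoro on this aromatic carbon gives a 7.0-fold higher number from compound 2 to compound 3 (0.84 log units; beyond the scatter) and so provides the first direct reading of this position, which compound 1 and compound 2 could not offer. The number at this position thus responds to the group it carries: it is lower with the large group, which brings an aromatic ring and an ether oxygen, than with the single fluorine atom. No measured property bears on this step, so the data assign it no cause.

The compounds shown leave open which part of the (4-bromobenzyl)oxy group matters: the bromine, the aromatic ring or the oxygen. A plain benzyloxy or a methoxy on this carbon would begin to separate these parts, and an amine there would test a quite different kind of group.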